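The source may report more compounds than this note shows. Statements on the series, on what has been measured and on what is new or still open speak of the compounds shown alone.

Compound 3 `COc1ccc(C(=O)O)cc1-c1cccc(COc2ccc3c(c2)CN(C2CCCC2)C3=O)c1` holds the lowest number among the values measured in an assay on HEK293 cells for positive allosteric modulation of metabotropic glutamate receptor 2 (Rattus norvegicus), read by thallium flux (on this read-out lower numbers stand for an effect already at smaller amounts and higher numbers for an effect only at larger amounts of compound), giving 80 nM. Compound 2 `CN(C)C(=O)c1cc(-c2cccc(COc3ccc4c(=O)n(C5CCCC5)sc4c3)c2)ccc1Cl` gives 980 nM, the nearest measured number, and that gap lies beyond the scatter. Compound 1 `O=C1c2ccc(OCc3cccc(-c4ccccc4)c3)cc2CN1C1CCCC1` gives only a limit in this assay, > 5000 nM, which is the limit of > 5000 nM in this assay, at which 1 of the 3 values shown sits. Among the measured compounds shown here, the one single-place step measured, an at least 62-fold lower number from compound 1 to compound 3 (1.79 log units; beyond the scatter), shows that the 5-carboxy-2-methoxyphenyl group rather than plain phenyl carries most of the activity seen in compound 3.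

Compound 4 `O=C(O)c1ccc(Cl)c(-c2cccc(COc3ccc4c(c3)CN(C3CCCC3)C4=O)c2)c1` differs from compound 3 in one place: chloro in place of methoxy on an aromatic carbon. For the measured compounds named here, no measured step exchanges methoxy for chloro, and compound 2 carries its chloro on a different core with a dimethylamide rather than a carboxy group, so it does not speak to the exchange directly. The carboxy group kept in compound 4 is the part that an at least 62-fold lower number from compound 1 to compound 3 (1.79 log units; beyond the scatter) marks as decisive. Compound 4 is therefore estimated at 150 nM, with a range of 50 nM to 500 nM. The step expected in this assay, a 1.9-fold higher number from compound 3 to compound 4 (0.27 log units; within the scatter), is not expected to exceed the scatter clearly in either direction.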

Compound 4, half-maximal effective concentration: 90 nM
Estimate against measurement, compound 4: 1.7-fold (0.22 log units) above; the range from low to high includes it.
By their numbers in this assay, from the lowest: compounds 3 and 4 (each within the scatter of the next); then compound 2. At a limit, above all of these: compound 1.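

In this assay, chloro in place of methoxy on this aromatic carbon, ortho to a large group and para to a carboxy group, gives a 1.1-fold higher number from compound 3 to compound 4 (0.05 log units; within the scatter), so the two groups cannot be told apart at this position. The large step away from plain phenyl appears with chloro, an at least 55-fold lower number from compound 1 to compound 4 (1.74 log units; beyond the scatter), as it does with methoxy, an at least 62-fold lower number from compound 1 to compound 3 (1.79 log units; beyond the scatter), so in these compounds it does not depend on methoxy being present. The value of compound 1 in both steps is a limit: the limit of > 5000 nM in this assay, at which 1 of the 4 values shown sits.

On these data alone, whether this position needs a substituent at all remains open, since neither hydrogen nor a group such as fluoro or methyl appears there alongside the carboxy group. Also open, as far as these compounds go, is whether a nitrile or a primary amide could stand in place of the carboxy group on the shared core.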